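A few compounds are considered here, and "the series" means these few. Any claim that something is new, unique, unknown or untested is made for them only; others in the source may bear on it.

Measured so far in a functional assay on A549 cells (Homo sapiens) for antiproliferative activity, read by MTT assay, with a stated time of 72 h; on this read-out lower numbers stand for stronger inhibition and higher numbers for weaker inhibition:
- compound 1 `NC1=NC2(CCOCC2)N(OCCCOc2cccc(Cl)c2)C(N)=N1` gives 150 nM
- compound 2 `NC1=NC2(CCOCC2)N(OCCCOc2ccc(Cl)cc2)C(N)=N1` gives 360 nM
- compound 3 `NC1=NC2(CCOCC2)N(OCCCOc2ccccc2Br)C(N)=N1` gives 160 nM

Compound 3 stands second highest of these three numbers; compound 1 lies nearest, as the step of a 1.1-fold higher number from compound 1 to compound 3 (0.03 log units; within the scatter) shows, while compound 2 lies furthest, as a 2.3-fold lower number from compound 2 to compound 3 (0.35 log units; beyond the scatter) shows. Compound 4 `COc1ccc(OCCCON2C(N)=NC(N)=NC23CCOCC3)cc1` has not been measured. The change is 4-methoxyphenyl in place of 2-bromophenyl on an oxygen on a saturated carbon. The step of a 2.3-fold lower number from compound 2 to compound 3 (0.35 log units; beyond the scatter) and the step of a 2.4-fold higher number from compound 1 to compound 2 (0.38 log units; beyond the scatter) both bear on it, since a 4-chlorophenyl gave a higher number than either the 3-chlorophenyl or the 2-bromophenyl. A modest step towards a higher number, a 2.5-fold higher number from compound 3 to compound 4 (0.40 log units; beyond the scatter), is therefore expected. Compound 4 is estimated at 400 nM, within 150 nM to 1000 nM.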

Compound 4, half-maximal inhibitory concentration: 660 nM
Compound 4: middle estimate off by 1.7-fold (0.22 log units), on the low side; the range from low to high includes it.
By their numbers in this assay, from the lowest: compounds 1 and 3 (each within the scatter of the next); then compounds 2 and 4 (each within the scatter of the next).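

In this assay, methoxy in place of chloro on an aromatic carbon gives a 1.8-fold higher number from compound 2 to compound 4 (0.26 log units; within the scatter), so 4-methoxyphenyl and 4-chlorophenyl cannot be told apart. 4-Methoxyphenyl does stand apart from the other two groups, with a 4.1-fold higher number from compound 3 to compound 4 (0.62 log units; beyond the scatter) and a 4.4-fold higher number from compound 1 to compound 4 (0.64 log units; beyond the scatter), so both 4-substituted compounds now give higher numbers than compound 1 and compound 3. No other measurement accompanies these numbers to explain that gap.

Still open, on these data alone, is whether 3-methoxyphenyl would read like 3-chlorophenyl or like 4-methoxyphenyl. Plain phenyl and a ring bearing an amine also remain open.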